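Phenoxy for Bromo on Two Related Cores

A few compounds are considered here, and "the series" means these few. Any claim that something is new, unique, unknown or untested is made for them only; others in the source may bear on it.

Compound 1 `O=c1[nH]c(=O)n([C@H]2C[C@H](O)[C@@H](CO)O2)cc1-c1cn(-c2ccc(Br)cc2)nn1` and compound 2 `O=c1[nH]c(=O)n([C@H]2C[C@H](O)[C@@H](CO)O2)cc1-c1cn(-c2ccc(Oc3ccccc3)cc2)nn1` share one core; compound 3 `O=c1[nH]c(=O)n([C@H]2C[C@H](O)[C@@H](CO)O2)cc1-c1cnnn1-c1ccc(Br)cc1` and compound 4 `O=c1[nH]c(=O)n([C@H]2C[C@H](O)[C@@H](CO)O2)cc1-c1cnnn1-c1ccc(Oc2ccccc2)cc1` share another. Compound 3 has the same atoms as compound 1, joined differently; the difference between the two cores is not broken down here. In an ADME assay on CCRF-CEM cells (Homo sapiens) for cytotoxicity, read by cell counting, with a stated time of 3 days (a lower number here means a stronger inhibitor, a higher number a weaker inhibitor), compound 1 gives 1800 nM, compound 2 gives 800 nM, and compound 3 gives 47000 nM. The change from compound 1 to compound 2 is phenoxy in place of bromo on an aromatic carbon, and it made a 2.3-fold lower number from compound 1 to compound 2 (0.35 log units; beyond the scatter). The same change, (phenoxy in place of bromo on an aromatic carbon), leads from compound 3 to compound 4, which has not yet been measured in this assay. Because the earlier step was a 2.3-fold lower number from compound 1 to compound 2 (0.35 log units; beyond the scatter), a step of similar size is expected here, a 2.4-fold lower number from compound 3 to compound 4 (0.37 log units; beyond the scatter). Compound 4 is therefore estimated at 20000 nM, between 8000 nM and 50000 nM.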

Compound 4, half-maximal inhibitory concentration: 107000 nM
Compound 4: middle estimate off by 5.4-fold (0.73 log units), on the low side; measured number above the stated range.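

In this assay, phenoxy in place of bromo did not repeat its earlier effect on the second core, where the change gave a 2.3-fold higher number from compound 3 to compound 4 (0.36 log units; beyond the scatter) instead. The two steps run in opposite directions, and the gap between them is larger than repeat measurements alone would give: the same change on two cores in this assay, a 2.3-fold lower number (0.35 log units; beyond the scatter) from compound 1 to compound 2 and a 2.3-fold higher number (0.36 log units; beyond the scatter) from compound 3 to compound 4, 5.1-fold (0.71 log units) apart, beyond the scatter of two such steps. In this series, then, the result of this change on one core cannot be assumed to hold on the other, although a single pair on each core does not show why the cores differ or how other changes would carry across.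

The compounds shown leave open how an amine or a carboxylic acid in the same place would behave on each core. They also leave open whether such groups would split the two cores in the same way.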